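Amide-to-urea switch on a shared core: antiproliferative outlook

The compounds below may be only part of what the source reports. "The series", "measured", "known", "first", "only" and "open" are said of these compounds alone.

Measured so far:
compound 1, `CCC(=O)N(C)c1ccc2[nH]c(-c3n[nH]c4ccccc34)cc2n1`, 15700 nM
compound 2, `CN(C(=O)C(C)(C)C)c1ccc2[nH]c(-c3n[nH]c4ccccc34)cc2n1`, 24400 nM
compound 3, `COc1ccc(C(=O)N(C)c2ccc3[nH]c(-c4n[nH]c5ccccc45)cc3n2)cc1`, 14600 nM

In a functional assay on A549 cells (Homo sapiens) for antiproliferative activity, read by MTT assay, with a stated time of 72 h (a higher number here means a weaker inhibitor, a lower number a stronger inhibitor), compound 3 has the lowest of the three numbers, yet it sits within the scatter of both compound 1 and compound 2. The steps of a 1.6-fold higher number from compound 1 to compound 2 (0.19 log units; within the scatter), a 1.1-fold lower number from compound 1 to compound 3 (0.03 log units; within the scatter) and a 1.7-fold lower number from compound 2 to compound 3 (0.22 log units; within the scatter) all stay within the scatter, so varying the group on the carbonyl carbon has so far changed nothing. Compound 4, `CN(C(=O)Nc1ccccc1)c1ccc2[nH]c(-c3n[nH]c4ccccc34)cc2n1`, differs from compound 3 in that (anilino in place of 4-methoxyphenyl on a carbonyl carbon). Within the data shown here, no measured step swaps a carbon group for a nitrogen group at this place, so nothing bears directly on it; the three small steps suggest no change beyond the scatter in this assay. Compound 4 is therefore expected to give 15000 nM, between 6000 nM and 40000 nM, an expected step of a 1.0-fold higher number from compound 3 to compound 4 (0.01 log units; within the scatter).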

Compound 4, half-maximal inhibitory concentration: 1430 nM
Beside the measured number, compound 4's estimate is 10-fold (1.02 log units) above it, and the stated range ends above it.
By their numbers in this assay, from the lowest: compound 4; then compounds 3, 1 and 2 (each within the scatter of the next).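

In this assay the anilino group stands apart from all three carbon groups on the carbonyl carbon, with a 10-fold lower number from compound 3 to compound 4 (1.01 log units; beyond the scatter), an 11-fold lower number from compound 1 to compound 4 (1.04 log units; beyond the scatter) and a 17-fold lower number from compound 2 to compound 4 (1.23 log units; beyond the scatter). Ethyl, tert-butyl and 4-methoxyphenyl had left this position looking unresponsive, but it does respond once a nitrogen-linked group carrying a hydrogen-bond donor takes their place. Nothing measured here explains the shift.

The compounds shown leave open whether that hydrogen is needed, which a methylanilino group would test. They also leave open whether a benzylamino or cyclohexylamino group would serve like anilino.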